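Writhing inhibition across aryl variants of a shared core

This account rests on a few compounds, and the source may have more. Where it says the series, first, only, none or still open, it means among the compounds named here.

Measured compounds:
compound 1 `O=C1N=C(C2C(=O)c3ccccc3C2=O)CC(c2ccccc2[N+](=O)[O-])N1` gives 35%
compound 2 `COc1ccc(C2CC(C3C(=O)c4ccccc4C3=O)=NC(=O)N2)cc1` gives 31%
compound 3 `O=C1N=C(C2C(=O)c3ccccc3C2=O)CC(/C=C/c2ccccc2)N1` gives 16%

In a functional assay on the whole organism for inhibition, with Mus musculus as the target, in the writhing test, with a stated time of 15 min, at a dose of 10 mg/kg (a lower number here means less inhibition, a higher number more inhibition at the dose given (going by the name of the read-out)), compound 2 stands second highest of the three numbers. Its nearest neighbour is compound 1, with a number 4 percentage points lower from compound 1 to compound 2 (within the scatter) within the scatter; the furthest is compound 3, with a number 15 percentage points lower from compound 2 to compound 3 (beyond the scatter) beyond the scatter, and a number 19 percentage points lower from compound 1 to compound 3 (beyond the scatter) of the same order. Compound 4 `CN(C)c1ccc(C2CC(C3C(=O)c4ccccc4C3=O)=NC(=O)N2)cc1` keeps the shared core and differs from compound 2 only in one place: dimethylamino in place of methoxy on an aromatic carbon. Going by the values given here, none of the measured steps alters a group on the aromatic ring; each swaps the whole group on the saturated ring carbon, so none bears closely on this change. The expected step is therefore a number 1 percentage points lower from compound 2 to compound 4 (within the scatter), not beyond the scatter. Compound 4 is estimated at 30%, with a range from 18% to 42%.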

Compound 4, a percentage reported as inhibition, in the whole organism at one dose (the size of the read-out at that dose, not a potency): 52%
For compound 4 the middle estimate is 22 percentage points below the measured one; the whole stated range lies below it.
By their numbers in this assay, from the lowest: compound 3; then compounds 2 and 1 (each within the scatter of the next); then compound 4.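

In this assay, a change on the aromatic carbon para to a large group moves the number well beyond the scatter (a number 21 percentage points higher from compound 2 to compound 4 (beyond the scatter)), so this position matters as well as the saturated ring carbon. The 4-(dimethylamino)phenyl group also stands clear of the other two groups (a number 17 percentage points higher from compound 1 to compound 4 (beyond the scatter); a number 36 percentage points higher from compound 3 to compound 4 (beyond the scatter)), which makes compound 4 the highest of the four. Nothing shown here explains the gain.

On these data alone, whether the gain is specific to dimethylamino stays open: a primary amine, diethylamino or a hydroxyl group on the same aromatic carbon would test this. With a single dose shown, the numbers give no potency order.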